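Thioether to ether on the shared core: compound 4

The source may hold more compounds than are shown below. What is called first, only, known or untested is meant among the compounds shown, and "the series" means these compounds.

The series shares the core of compound 1 `CCOC(=O)[C@H](CCC(=O)O)NC(=O)c1ccc(Sc2nc3cc(N)cc(N)c3nc2-c2ccccc2)cc1`, which in a functional assay on HOP-62 cells (Homo sapiens) for inhibition, read by sulforhodamine B assay, with a stated time of 48 h (a higher number here means a weaker inhibitor of growth, a lower number a stronger inhibitor of growth), gives 15500 nM. Its oxygen counterpart, compound 2 `CCOC(=O)[C@H](CCC(=O)O)NC(=O)c1ccc(Oc2nc3cc(N)cc(N)c3nc2-c2ccccc2)cc1`, gives 36300 nM in this assay, so the two values sit apart from one another. Compound 3 `COc1ccc(Sc2nc3cc(N)cc(N)c3nc2-c2ccccc2)cc1` carries no amino acid tail. In this assay compound 3 is recorded only as a limit, < 100000 nM, and the bare value of compound 3 is therefore not known (the limit of < 100000 nM in this assay, at which 1 of the 3 values shown sits). Compound 4 `Nc1cc(N)c2nc(-c3ccccc3)c(Oc3ccc(F)cc3)nc2c1` differs from compound 3 by the change (4-fluorophenoxy in place of (4-methoxyphenyl)sulfanyl on an aromatic carbon), that is, 4-fluorophenoxy in place of (4-methoxyphenyl)sulfanyl on an aromatic carbon of the shared core. Among the compounds with values here, no measured pair in this set mirrors that exact change, so the expected step from compound 3 to compound 4 rests only on the limit of compound 3 and is estimated to be a step that the limit leaves unreadable from compound 3 to compound 4. Taking that together, compound 4 is expected to give about 40000 nM in this assay, with a plausible range from 10000 nM to 120000 nM.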

Compound 4, concentration for 50% growth inhibition: 21400 nM
Beside the measured number, compound 4's estimate is 1.9-fold (0.27 log units) above it; the measured number falls inside the stated range.
By their numbers in this assay, from the lowest: compounds 1, 4 and 2 (each within the scatter of the next, the first and the last beyond it).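

In this assay no size can be read for the change from compound 3 to compound 4, because compound 3 stands only as a limit: the limit of < 100000 nM in this assay, at which 1 of the 4 values shown sits. The compounds shown leave open how far 4-fluorophenoxy and (4-methoxyphenyl)sulfanyl differ on the shared core.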